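Acylsulfonamide Tail Swap on a Stable Triazine Anilide

This account rests on a few compounds, and the source may have more. Where it says the series, first, only, none or still open, it means among the compounds named here.

Measured compounds:
- compound 1, `Cc1ccccc1S(=O)(=O)NC(=O)c1ccc(Nc2nc(NC3(c4ccc(Cl)cc4)CC3)nc(OCC(F)(F)F)n2)cc1`: 100%
- compound 2, `CCCCCNc1nc(Nc2ccc([N+](=O)[O-])cc2)nc(OCC(F)(F)F)n1`: 35%

In an ADME assay on microsomes from liver (Rattus norvegicus) for metabolic stability, with a stated time of 10 min (on this read-out lower numbers stand for a less stable compound and higher numbers for a more stable compound), compound 1 gives 100%, the highest of the two numbers recorded. Compound 2 shares no single-point relationship with compound 1; in this assay compound 2 gives 35%, a gap that lies beyond the scatter, and nothing more can be read from that pair.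

Compound 3, `CC(C)S(=O)(=O)NC(=O)c1ccc(Nc2nc(NC3(c4ccc(Cl)cc4)CC3)nc(OCC(F)(F)F)n2)cc1`, is not yet measured. It differs from compound 1 in one place: isopropyl in place of 2-methylphenyl on a sulfonyl sulfur. Among the compounds with values here, no measured step of this kind is available, so the direction of change rests on compound 1 alone, which sits at the top of this assay. Because compound 1 gives 100%, there is no room for an upward step, and the expected step of a number 15 percentage points lower from compound 1 to compound 3 (beyond the scatter) is a modest loss, possibly within the scatter. For compound 3 the estimate is 85%, with a range of 55% to 100%.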

Compound 3, percent of the compound remaining: 96%
Compound 3: middle estimate off by 11 percentage points, on the low side, within the range that was stated.
By their numbers in this assay, from the lowest: compound 2; then compounds 3 and 1 (each within the scatter of the next).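

In this assay the swap on the sulfonyl sulfur reads as a number 4 percentage points lower from compound 1 to compound 3 (within the scatter) and is the only measured step shown at this place. For this one pair, then, isopropyl stands in place of 2-methylphenyl with no difference that can be told from repeat scatter, so the aromatic ring of carbon is not required on this core for the compound to remain largely intact over the stated time. Nothing in hand explains this result.

Going by these compounds, whether the same holds for other groups on the sulfonyl sulfur, such as cyclopropyl, a longer chain like n-butyl, or a dimethylamine, stays open. Also open, on these data alone, is whether a tail swap of this kind would read the same on a core without the 1-(4-chlorophenyl)cyclopropyl amine, as the two values here lie close to the top of the read-out.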